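The compounds below may be only part of what the source reports. "The series", "measured", "known", "first", "only" and "open" are said of these compounds alone.

Compound 3 `C=CCn1c(=O)/c(=C\c2ccccc2OC)[nH]c(=O)/c1=C\c1ccccc1OC` is one of three compounds of a shared core tested in a functional assay on HL-60 cells (Homo sapiens) for cytotoxicity, read by CCK-8 assay, with a stated time of 72 h (a lower number here means a stronger inhibitor, a higher number a weaker inhibitor), in which compound 3 gives 15700 nM. Compound 1 `C=CCn1c(=O)/c(=C\c2cccc(C)c2)[nH]c(=O)/c1=C\c1ccccc1OC` gives 16700 nM in this assay, and the step of a 1.1-fold lower number from compound 1 to compound 3 (0.03 log units; within the scatter) shows that the two numbers lie within the scatter of each other, so neither can be called the stronger. Compound 2 `C=CCn1c(=O)/c(=C\c2ccc(F)c(Br)c2)[nH]c(=O)/c1=C\c1ccccc1OC` was reported in this assay only as "not active" (no number reported), without a number.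

Compound 4 `C=CCn1c(=O)/c(=C\c2ccccc2F)[nH]c(=O)/c1=C\c1ccccc1OC` differs from compound 3 at one position: fluoro in place of methoxy on an aromatic carbon. For the measured compounds named here, no measured step bears directly on this exchange; the only measured step, from compound 1 to compound 3, concerns the other aryl group and was within the scatter. On that basis the number for compound 4 in this assay is expected to stay close to that of compound 3, with the step of a 1.1-fold higher number from compound 3 to compound 4 (0.06 log units; within the scatter) expected to lie within the scatter. The estimate for compound 4 in this assay is 18000 nM, with a range from 8000 nM to 40000 nM.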

Compound 4, half-maximal inhibitory concentration: 18500 nM
The estimate for compound 4 lay 1.0-fold (0.01 log units) below the measured number; measured number inside the range.
By their numbers in this assay, from the lowest: compounds 3, 1 and 4 (each within the scatter of the next).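

With a 1.2-fold higher number from compound 3 to compound 4 (0.07 log units; within the scatter), the exchange of methoxy for fluoro removes one heavy atom and the one hydrogen-bond acceptor of the group without a difference that can be told in this assay. With a 1.1-fold higher number from compound 1 to compound 4 (0.04 log units; within the scatter), the 2-fluorophenyl group also cannot be told from the 3-methylphenyl group, so three aryl groups at this place now give numbers within the scatter of one another, while compound 2, with its bromo and fluoro aryl group, stands apart as reported not active. Nothing given here accounts for how closely these numbers agree. Going by these compounds, it remains open whether an amine or a carboxylic acid on this aromatic carbon would move the number beyond the scatter. Also open, on these data alone, is whether fluoro in place of methoxy on the other aryl group, held constant in all these compounds, would read the same.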